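Carboxy in Place of Nitro on a Shared Sulfonyl Anilide Core

The compounds below may be only part of what the source reports. "The series", "measured", "known", "first", "only" and "open" are said of these compounds alone.

The four compounds share a core and differ at a single aromatic carbon. In a functional assay (Cavia porcellus) with sulfonylurea receptors; K-ATP channels (Homo sapiens) as the target (on this read-out higher numbers stand for weaker inhibition and lower numbers for stronger inhibition), compound 1 `CC(O)(C(=O)Nc1ccc(S(=O)(=O)c2ccccc2)c(C#N)c1)C(F)(F)F` gives 3800 nM. Compound 2 `COc1cc(NC(=O)C(C)(O)C(F)(F)F)ccc1S(=O)(=O)c1ccccc1` gives 5900 nM. For compound 3 `CC(O)(C(=O)Nc1ccc(S(=O)(=O)c2ccccc2)c([N+](=O)[O-])c1)C(F)(F)F` this assay reports only a limit and not a number, > 30000 nM; it sits at the limit of > 30000 nM in this assay, at which 1 of the 3 values shown sits. The steps of an at least 7.8-fold higher number from compound 1 to compound 3 (0.89 log units; beyond the scatter) and an at least 5.0-fold higher number from compound 2 to compound 3 (0.70 log units; beyond the scatter) both leave the nitro compound as the weakest inhibitor shown. Compound 4 `CC(O)(C(=O)Nc1ccc(S(=O)(=O)c2ccccc2)c(C(=O)O)c1)C(F)(F)F` differs from compound 3 by carboxy in place of nitro on an aromatic carbon. For the measured compounds named here, no measured step covers a carboxy group, so the account can only lean on where compound 3 stands. Compound 4 is therefore expected to remain weak, with an at least 1.2-fold lower number from compound 3 to compound 4 (0.07 log units; that floor lies within the scatter) as the expected step. The estimate for compound 4 is 25000 nM, between 8000 nM and 80000 nM.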

Compound 4, half-maximal inhibitory concentration: > 30000 nM
Compound 4 was reported as a limit (the forecaster's own chance of this, stated with the estimate: 50%); middle value at least 1.2-fold (0.07 log units) from the limit.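

In this assay, compound 4 stands at a limit of the assay and not at a number, as compound 3 does, so the step between them cannot be read: the limit of > 30000 nM in this assay, at which 2 of the 4 values shown sit. The carboxy change still gives an at least 7.8-fold higher number from compound 1 to compound 4 (0.89 log units; beyond the scatter) and an at least 5.0-fold higher number from compound 2 to compound 4 (0.70 log units; beyond the scatter). At this carbon, ortho to a phenylsulfonyl group, carboxy thus joins nitro at the limit, while nitrile and methoxy give numbers.

On these data alone, how far compound 3 and compound 4 lie past the limit stays open. So does whether an amine or a carboxamide here would give a number or also reach the limit.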